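Swapping methylsulfonyl for nitro on a second core

The source may hold more compounds than are shown below. What is called first, only, known or untested is meant among the compounds shown, and "the series" means these compounds.

Compound 1, `CS(=O)(=O)c1ccc(C(=O)N2CCC(n3cncc3-c3ccc(OS(=O)(=O)c4cccc(C#N)c4)cc3)CC2)cc1`, is the reference. In an assay on HEK293 cells for antagonist activity at P2X purinoceptor 7 (Homo sapiens), read by fluorescence, with a stated time of 2 h (a lower number here means a stronger inhibitor, a higher number a weaker inhibitor), compound 1 gives 143 nM. Compound 2, `N#Cc1cccc(S(=O)(=O)Oc2ccc(-c3cncn3C3CCN(C(=O)c4ccc([N+](=O)[O-])cc4)CC3)cc2)c1`, differs from it by nitro in place of methylsulfonyl on an aromatic carbon, and the change gave a 3.2-fold lower number from compound 1 to compound 2 (0.50 log units; beyond the scatter). In this assay compound 2 gives 45 nM. Compound 3, `CNC(=O)c1cccc(S(=O)(=O)Oc2ccc(-c3cncn3C3CCN(C(=O)c4ccc(S(C)(=O)=O)cc4)CC3)cc2)c1`, has a second core that differs from compound 1 by methylcarbamoyl in place of cyano on an aromatic carbon, and compound 3 gives 202 nM in this assay, which is within the scatter of compound 1. Compound 4, `CNC(=O)c1cccc(S(=O)(=O)Oc2ccc(-c3cncn3C3CCN(C(=O)c4ccc([N+](=O)[O-])cc4)CC3)cc2)c1`, carries the same change on that second core: nitro in place of methylsulfonyl on an aromatic carbon, at a place described in the same words as before.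

The expectation is that the step from compound 3 to compound 4 repeats the earlier one, so a step of a 3.1-fold lower number from compound 3 to compound 4 (0.49 log units; beyond the scatter) is estimated, resting on a 3.2-fold lower number from compound 1 to compound 2 (0.50 log units; beyond the scatter). Compound 4 is therefore expected to give about 65 nM in this assay, likely between 30 nM and 140 nM.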

Compound 4, half-maximal inhibitory concentration: 62 nM
The estimate for compound 4 lay 1.0-fold (0.02 log units) above the measured number; the measured number falls inside the stated range.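

Nitro in place of methylsulfonyl gave a 3.3-fold lower number from compound 3 to compound 4 (0.51 log units; beyond the scatter), matching the step on the first core: the same change on two cores in this assay, a 3.2-fold lower number (0.50 log units; beyond the scatter) from compound 1 to compound 2 and a 3.3-fold lower number (0.51 log units; beyond the scatter) from compound 3 to compound 4, 1.0-fold (0.01 log units) apart, within the scatter of two such steps Methylcarbamoyl in place of cyano, read between the two nitro compounds, gave a 1.4-fold higher number from compound 2 to compound 4 (0.14 log units; within the scatter), which also matches its counterpart between the two methylsulfonyl compounds: the same change on two cores in this assay, a 1.4-fold higher number (0.15 log units; within the scatter) from compound 1 to compound 3 and a 1.4-fold higher number (0.14 log units; within the scatter) from compound 2 to compound 4, 1.0-fold (0.01 log units) apart, within the scatter of two such steps Across these four compounds the two changes therefore add up simply in this assay, but this rests on one pair of cores in one assay and does not show that the nitro step holds on other cores, or why it occurs.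

As far as these compounds go, whether an amine or a carboxylic acid on the same aromatic carbon would behave like nitro remains open. So does whether the nitro step would keep its size with a longer chain in place of methylcarbamoyl.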